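The source may hold more compounds than are shown below. What is called first, only, known or untested is meant among the compounds shown, and "the series" means these compounds.

For the measured compounds named here, in an ADME assay on cells (Hepatocyte, Homo sapiens) for metabolic stability, with a stated time of 30 min (a lower number here means that less of the compound is left, a higher number that more of the compound is left), compound 3 (`O=C(OC1CCC(CN2CCN(c3cc(=O)c4cc(C(F)(F)F)cc([N+](=O)[O-])c4s3)CC2)CC1)C1CCCCC1`) gives 2.8%, the lowest number of the three measured so far. Compound 1 (`O=C(OC1CCC(CN2CCN(c3cc(=O)c4cc(C(F)(F)F)cc([N+](=O)[O-])c4s3)CC2)CC1)c1ccccc1`) gives 56.4% and compound 2 (`CS(=O)(=O)NC1CCC(CN2CCN(c3cc(=O)c4cc(C(F)(F)F)cc([N+](=O)[O-])c4s3)CC2)CC1`) gives 105%.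

The next compound is compound 4 (`O=C(OC1CCC(CN2CCN(c3cc(=O)c4cc(C(F)(F)F)cc([N+](=O)[O-])c4s3)CC2)CC1)c1ccc(F)cc1`), and its change from compound 3 is this: 4-fluorophenyl in place of cyclohexyl on a carbonyl carbon. Here 4-fluorophenyl stands in place of cyclohexyl on a carbonyl carbon.

The closest measured step is a number 53.6 percentage points lower from compound 1 to compound 3 (beyond the scatter), large and beyond the scatter, with cyclohexyl in place of phenyl on a carbonyl carbon. Compound 4 runs in the opposite sense, from cyclohexyl back to an aromatic ring. The step of a number 102.2 percentage points lower from compound 2 to compound 3 (beyond the scatter) is also large, but it exchanges a different group and bears only loosely on this change. Going by the values given here, no measured pair shows what the fluorine on the phenyl adds, so the range stays wide.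

A large upward step is therefore expected, with compound 1 at 56.4% as the guide. The expected step is a number 47.2 percentage points higher from compound 3 to compound 4 (beyond the scatter). For compound 4 the estimated value is 50%, with an expected range of 25% to 78%.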

Compound 4, percent of the compound remaining: 3%
Beside the measured number, compound 4's estimate is 47 percentage points above it; the measured number lies below the stated range.
By their numbers in this assay, from the lowest: compounds 3 and 4 (each within the scatter of the next); then compound 1; then compound 2.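

Working from the benzoyloxy compound, fluoro in place of hydrogen on an aromatic carbon is a large change in this assay (a number 53.4 percentage points lower from compound 1 to compound 4 (beyond the scatter)), so the retention seen in compound 1 does not carry over to its 4-fluorophenyl counterpart. An aromatic ring on the carbonyl carbon is therefore not enough on its own to separate this series from the cyclohexyl compound (a number 0.2 percentage points higher from compound 3 to compound 4 (within the scatter)). The methanesulfonamido compound stays well apart from the fluorinated compound (a number 102 percentage points lower from compound 2 to compound 4 (beyond the scatter)), and within this set only the unsubstituted phenyl ring gives an intermediate number.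

Still open, on these data alone, is whether a chloro or methoxy group on the same aromatic ring would behave like hydrogen or like fluoro. Nothing available here accounts for the size of these steps.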